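Saturating the Vinyl Group on the Nitrogen Chain

A few compounds are considered here, and "the series" means these few. Any claim that something is new, unique, unknown or untested is made for them only; others in the source may bear on it.

Measured compounds:
Compound 1, `COc1cc(C(=O)NS(=O)(=O)c2ccccc2C)ccc1Cc1cn(C)c2ccc(C(=O)NCC3CCCC3)cc12` — in an assay on isolated protein for binding affinity to cysteinyl leukotriene receptor 1 (Cavia porcellus) (a higher number here means a more potent compound, by a factor of ten per unit of this negative logarithm, a lower number a less potent compound), compound 1 gives 8.4.
Compound 2, `CCCn1cc(Cc2ccc(C(=O)NS(=O)(=O)c3ccccc3C)cc2OC)c2cc(C(=O)NCC(CC)CC)ccc21` — in this assay compound 2 gives 8.9.
Compound 3, `C=CCn1cc(Cc2ccc(C(=O)NS(=O)(=O)c3ccccc3C)cc2OC)c2cc(C(=O)NCC3CCCC3)ccc21` — in this assay compound 3 gives 8.3.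

Among these three numbers compound 3 has the lowest. Its nearest neighbour is compound 1, whose value lies within the scatter of it, so the two cannot be told apart; compound 2 stands furthest away, beyond the scatter, but compound 2 differs from compound 3 in more than one place, so the two values alone say nothing about any single change.

Compound 4, `CCCn1cc(Cc2ccc(C(=O)NS(=O)(=O)c3ccccc3C)cc2OC)c2cc(C(=O)NCC3CCCC3)ccc21`, has not yet been measured. It differs from compound 3 in one place: ethyl in place of vinyl on a saturated chain carbon bound to an aromatic nitrogen. Among the compounds with values here, the one measured step on the same saturated chain carbon is a number 0.10 log units lower from compound 1 to compound 3 (within the scatter), which was within the scatter. That step adds a vinyl group; the present step only removes its double bond, a smaller change in kind. Nothing measured here points to a shift beyond the scatter in either direction.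

Compound 4 is therefore expected to come out close to compound 3, at about 8.5, with a likely range from 8 to 9. The step from compound 3 to compound 4 is estimated as a number 0.20 log units higher from compound 3 to compound 4 (within the scatter).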

Compound 4, negative logarithm of the antagonist equilibrium constant: 8.7
Beside the measured number, compound 4's estimate is 0.20 log units below it; low and high end bracket the measured number.
By their numbers in this assay, from the lowest: compounds 3, 1, 4 and 2 (each within the scatter of the next, the first and the last beyond it).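

Vinyl and ethyl carry the same count of heavy atoms on this saturated chain carbon bound to an aromatic nitrogen, yet in this assay the loss of the double bond, which turns allyl into propyl, gives a number 0.40 log units higher from compound 3 to compound 4 (beyond the scatter). Within the data shown here, this is the first step at this position to leave the scatter, whereas the two steps from hydrogen stay inside it, with vinyl giving a number 0.10 log units lower from compound 1 to compound 3 (within the scatter) and ethyl giving a number 0.30 log units higher from compound 1 to compound 4 (within the scatter), so the separation appears only between the two groups and not between either of them and hydrogen. At the other place that varies, a saturated chain carbon bound to an amide-type nitrogen, cyclopentyl in place of pentan-3-yl gives a number 0.20 log units lower from compound 2 to compound 4 (within the scatter), a swap that cannot be told from the scatter.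

As far as these compounds go, it remains open whether a longer chain such as butyl, or a chain ending in an amine or a carboxylic acid, would follow propyl or allyl at this position, and whether the gap between allyl and propyl also holds alongside pentan-3-yl. Nothing available here explains why the double bond makes this difference.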